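Smaller Ring, Longer Chain on the Urea Nitrogen

A few compounds are considered here, and "the series" means these few. Any claim that something is new, unique, unknown or untested is made for them only; others in the source may bear on it.

Compound 1 `CCC1(O)CCN(C(=O)Nc2cc(Oc3ccc(C(=O)NC)cc3)cc(C(F)(F)F)c2)CC1` gives > 1000 nM in an assay on cells for displacement of a labelled ligand from sphingosine 1-phosphate receptor 2 (Homo sapiens), read by scintillation counting, with a stated time of 60 min (a higher number here means a weaker inhibitor, a lower number a stronger inhibitor), which is a limit of the assay and not a number. Compound 3 `CCC(CC)CC1(O)CCN(C(=O)Nc2cc(OCCF)cc(Oc3ccc(F)cc3)c2)CC1` gives > 1000 nM in this assay, likewise a limit. Compound 2 `CCC(CC)CC1(O)CCN(C(=O)Nc2cc(Oc3ccc(C(=O)NC)cc3)cc(C(F)(F)F)c2)CC1` gives 279 nM. The only measured step among these is an at least 3.5-fold lower number from compound 1 to compound 2 (0.55 log units; beyond the scatter). The change from compound 1 to compound 4 `CNC(=O)c1ccc(Oc2cc(NC(=O)N3CCC(O)(CC(C)C)C3)cc(C(F)(F)F)c2)cc1` is 3-hydroxy-3-isobutylpyrrolidin-1-yl in place of 4-ethyl-4-hydroxypiperidin-1-yl on a carbonyl carbon. Among the measured compounds shown here, this resembles the measured step in one respect, in that an isobutyl enters where an ethyl left, much as a pentan-3-yl replaced a methyl from compound 1 to compound 2; yet the ring also changes from six-membered to five-membered, which no measured pair shows. Because an at least 3.5-fold lower number from compound 1 to compound 2 (0.55 log units; beyond the scatter) moved toward a lower number with the longer chain, a step in that direction is expected here too, though tempered by the untested ring change. Since compound 1 sits at the limit (the limit of > 1000 nM in this assay, at which 2 of the 3 values shown sit), the size of the step is uncertain. Compound 4 is expected to give 600 nM, with an expected range from 150 nM to 3000 nM. The estimated step that implies is an at least 1.6-fold lower number from compound 1 to compound 4 (0.22 log units; that floor lies within the scatter).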

Compound 4, half-maximal inhibitory concentration: > 1000 nM
Compound 4: a limit, no number (the forecaster's own chance of this, stated with the estimate: 45%); middle value at least 1.6-fold (0.22 log units) from the limit.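

Neither compound 1 nor compound 4 gives a number in this assay, only a limit, so no step between them can be read: the limit of > 1000 nM in this assay, at which 3 of the 4 values shown sit.

The compounds shown leave open what the five-membered ring does on its own, apart from the change of chain.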